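Series notes: aryl amide change on the shared core

The source may report more compounds than this note shows. Statements on the series, on what has been measured and on what is new or still open speak of the compounds shown alone.

Among the measured compounds shown here, compound 1 `Cc1cc(NC(=O)CN2CCC(c3cccc[n+]3[O-])CC2)ccc1F` has the lowest of the two numbers so far in a functional assay on HEK293 cells for agonist activity at D(4) dopamine receptor (Homo sapiens), read by FLIPR; a lower number here means that less compound is needed, a higher number that more compound is needed for the effect; compound 1 gives 18 nM. Compound 2 `O=C(NCN1CCC(c2cccc[n+]2[O-])CC1)c1ccc2ccccc2c1` differs from it in more than one place, so only the two values can be set side by side: in this assay compound 2 gives 115 nM, a higher number than compound 1 and beyond the scatter. Compound 3 `O=C(CN1CCC(c2cccc[n+]2[O-])CC1)Nc1cccc(Cl)c1` has not been measured. It differs from compound 1 in one place: 3-chlorophenyl in place of 4-fluoro-3-methylphenyl on an amide-type nitrogen. For the measured compounds named here, no step between measured compounds exists for this kind of change, so no measured step can be carried over. A small step is expected, towards a higher number, likely near the edge of the scatter; the expected step is a 1.9-fold higher number from compound 1 to compound 3 (0.29 log units; within the scatter). For compound 3 the estimate in this assay is 35 nM, with a range from 12 nM to 110 nM.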

Compound 3, half-maximal effective concentration: 62 nM
For compound 3 the middle estimate is 1.8-fold (0.25 log units) below the measured one; the range from low to high includes it.
By their numbers in this assay, from the lowest: compound 1; then compounds 3 and 2 (each within the scatter of the next).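

Among the compounds shown here, on the amide-type nitrogen of the shared core, 3-chlorophenyl in place of 4-fluoro-3-methylphenyl gives in this assay a 3.4-fold higher number from compound 1 to compound 3 (0.54 log units; beyond the scatter) and this is the first single-place step. The group on this nitrogen therefore matters to the read-out: even an exchange of one carbon-only aromatic ring for another, with no hydrogen-bond donors or acceptors on either side, moves the number beyond the scatter, though only modestly. No supporting data on the compounds bear on why the number moves.

From the compounds shown here alone, the step changes the chlorine, the fluorine and the methyl together, so the share of each stays open. Also open, going by these compounds, is how this position responds to a group of another kind, such as a nitrile or a carboxylic acid on the phenyl ring, or an amine in place of the ring.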